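Dropping the methoxy from the aryl ring of compound 1

This account rests on a few compounds, and the source may have more. Where it says the series, first, only, none or still open, it means among the compounds named here.

For the measured compounds named here, compound 1 `COc1cccc(N2CCN(C(=O)C(C)N3C(=O)CCC3=O)CC2)c1` gives 25% in a functional assay on the whole organism (strain Swiss) with Mus musculus as the target, in the maximal electroshock model, with a stated time of 0.25 h, at a dose of 100 mg/kg by the intraperitoneal route (a higher number here means a stronger effect of the compound at the dose given, a lower number a weaker effect), and stands lowest of the two numbers measured so far. Going by the values given here, compound 2 `COCC(C(=O)N1CCN(c2cccc(C(F)(F)F)c2)CC1)N1C(=O)CCC1=O` gives 100% in this assay, a value beyond the scatter above compound 1, but no single-point step links the pair. Compound 3 `CC(C(=O)N1CCN(c2ccccc2)CC1)N1C(=O)CCC1=O` differs from compound 1 by hydrogen in place of methoxy on an aromatic carbon. Among the compounds with values here, with no comparable step in hand, an expected change of a number 10 percentage points higher from compound 1 to compound 3 (within the scatter) is assumed, a modest rise that may well stay within the scatter. Compound 3 is therefore expected to give 35% in this assay, with a range from 10% up to 75% around that estimate.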

Compound 3, a percentage reported as activity, at one dose (the size of the read-out at that dose, not a potency): 50%
For compound 3 the middle estimate is 15 percentage points below the measured one, within the range that was stated.
By their numbers in this assay, from the lowest: compound 1; then compound 3; then compound 2.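

Hydrogen in place of methoxy on the aromatic carbon gives the first readable step of the series in this assay (a number 25 percentage points higher from compound 1 to compound 3 (beyond the scatter)). The methoxy of compound 1 is therefore not required for a response at this dose, and the plain phenyl of compound 3 reads higher. Nothing at hand accounts for this step.

As far as these compounds go, whether an amine or a hydroxyl at this place would match hydrogen remains open. So does whether the 3-methoxyphenyl to phenyl step would hold with a longer chain on the shared core.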